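A few compounds are considered here, and "the series" means these few. Any claim that something is new, unique, unknown or untested is made for them only; others in the source may bear on it.

Compound 1 `O=C(Nc1ccc(Oc2ccnc3[nH]ccc23)c(F)c1)c1cc(-c2ccc(F)cc2)ccn1`: 710 nM
Compound 2 `O=C(Nc1ccc(Oc2ccnc3[nH]ccc23)c(F)c1)c1cc(-c2ccc(C(F)(F)F)cc2)ccn1`: 4350 nM

In a functional assay on PC-3 cells (Homo sapiens) for cytotoxicity, read by MTT assay, with a stated time of 72 h (a lower number here means a stronger inhibitor, a higher number a weaker inhibitor), compound 1 gives 710 nM, and compound 2 gives 4350 nM. Among the compounds with values here, of these two numbers, compound 2 has the higher one, and its only neighbour is compound 1, separated from it by the single measured step, a 6.1-fold higher number from compound 1 to compound 2 (0.79 log units; beyond the scatter). Compound 3 `O=C(Nc1ccc(Oc2ccnc3[nH]ccc23)c(F)c1)c1cc(-c2ccc(F)cc2F)ccn1` has not yet been measured. It differs from compound 2 in one place: 2,4-difluorophenyl in place of 4-(trifluoromethyl)phenyl on an aromatic carbon. Within the data shown here, the only measured step that bears on this change is a 6.1-fold higher number from compound 1 to compound 2 (0.79 log units; beyond the scatter), in which a trifluoromethyl replaced a fluoro on the phenyl ring. Compound 3 brings a fluoro back onto that ring, with a second fluoro beside it in the 2,4-difluorophenyl group, so most of that step is expected to be undone in this assay. The expected step is a 5.4-fold lower number from compound 2 to compound 3 (0.74 log units; beyond the scatter). Compound 3 is therefore estimated at 800 nM, with a range from 300 nM to 2500 nM.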

Compound 3, half-maximal inhibitory concentration: > 10000 nM
Compound 3: a limit, no number (the forecaster's own chance of this, stated with the estimate: 2%); at least 12-fold (1.09 log units) between middle value and limit.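

In this assay the result for compound 3 is a limit of the assay and not a number: the limit of > 10000 nM in this assay, at which 1 of the 3 values shown sits.

Fluoro in place of hydrogen on the phenyl ring gives an at least 14-fold higher number from compound 1 to compound 3 (1.14 log units; beyond the scatter), so a single small addition to this group, on the carbon opposite the ring nitrogen, can matter more than the earlier trifluoromethyl change did. Replacing 4-(trifluoromethyl)phenyl with 2,4-difluorophenyl gives an at least 2.2-fold higher number from compound 2 to compound 3 (0.36 log units; beyond the scatter), so here the group with fewer heavy atoms has the higher number, and the earlier step, where trifluoromethyl in place of fluoro raised the number, gave no hint of this.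

As far as these compounds go, it remains open whether only the added fluoro has this effect, or whether a methyl, a methoxy or an amine on the same ring would do the same. From the compounds shown here alone, how far compound 3 lies past its limit also remains unknown.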